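Working notes: from compound 2 to compound 3

The source may hold more compounds than are shown below. What is called first, only, known or untested is meant among the compounds shown, and "the series" means these compounds.

Measured so far in a physicochemical assay for lipophilicity, measured as octanol-water partition, at pH 7.4; a higher number here means a more lipophilic compound, a lower number a more polar compound:
- compound 1 `Cc1cc(Cn2c(=O)[nH]c3c(N)nc(C(F)(F)F)cc32)no1`: 2.1
- compound 2 `CN1CCN(c2ccc(Cn3c(=O)[nH]c4c(N)nc(C(F)(F)F)cc43)cn2)CC1`: 1.8

With only these two values in hand, compound 2 lies within the usual scatter of compound 1, so this assay does not separate them. Compound 3 `COc1ccc(Cn2c(=O)[nH]c3c(N)nc(C(F)(F)F)cc32)cn1` has not yet been measured. It differs from compound 2 in one place: methoxy in place of 4-methylpiperazin-1-yl on an aromatic carbon, next to the ring nitrogen and para to a large group. Among the compounds with values here, no measured pair isolates this change, so the expectation is loose. A moderate upward step in this assay, probably beyond the scatter, is expected. The estimated change is a number 0.70 log units higher from compound 2 to compound 3 (beyond the scatter). For compound 3 the expected value is 2.5, with an estimated range from 2 to 3.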

Compound 3, distribution coefficient: 2.8
Compound 3: middle estimate off by 0.30 log units, on the low side; the measured number falls inside the stated range.
By their numbers in this assay, from the lowest: compounds 2 and 1 (each within the scatter of the next); then compound 3.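

In this assay, methoxy in place of 4-methylpiperazin-1-yl on the aromatic carbon next to the ring nitrogen gives a number 1.00 log units higher from compound 2 to compound 3 (beyond the scatter) and so produces the first separation in the series beyond the scatter. The change of the whole group on the saturated chain carbon, 6-methoxypyridin-3-yl in place of 5-methyl-1,2-oxazol-3-yl, gives a number 0.70 log units higher from compound 1 to compound 3 (beyond the scatter) and leaves compound 3 with the highest number of the three, clear of both other compounds. Nothing available explains either step.

On these data alone, the swap from compound 2 to compound 3 removes one group and adds another in a single move, so the share of each in the step stays open. Where a dimethylamino group or a longer alkoxy chain on that same aromatic carbon would fall relative to these compounds also remains unknown.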